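Halogen swap on the benzylsulfanyl arm of compound 2

The source may hold more compounds than are shown below. What is called first, only, known or untested is meant among the compounds shown, and "the series" means these compounds.

In an ADME assay on A-431 cells (Homo sapiens) for cytotoxicity, with a stated time of 48 h (on this read-out lower numbers stand for stronger inhibition and higher numbers for weaker inhibition), compound 1 `CSc1nnc(-c2cc([N+](=O)[O-])cc([N+](=O)[O-])c2)n1Cc1ccccc1` gives > 30000 nM, which is a limit of the assay rather than a number. Compound 2 `O=[N+]([O-])c1cc(-c2nnc(SCc3ccc(Br)cc3)n2Cc2ccccc2)cc([N+](=O)[O-])c1` gives > 30000 nM in this assay, again a limit. Both values sit at the limit of > 30000 nM in this assay, at which 2 of the 2 values shown sit, so the step that the two limits leave unreadable from compound 1 to compound 2 cannot be read. Compound 3 `O=[N+]([O-])c1cc(-c2nnc(SCc3ccc(Cl)cc3)n2Cc2ccccc2)cc([N+](=O)[O-])c1` carries chloro in place of bromo on an aromatic carbon. No readable measured step bears on this change, and compound 2 itself stands only at the limit, so no shift beyond the scatter is expected. The step expected is a step that the limit leaves unreadable from compound 2 to compound 3. Compound 3 is estimated at 40000 nM, range 20000 nM to 100000 nM, most likely reported once more as a limit.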

Compound 3, half-maximal inhibitory concentration: > 30000 nM
Compound 3: no number, only a limit (the forecaster's own chance of this, stated with the estimate: 85%); the middle value is on the limit's open side.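

Within the data shown here, compound 3 stays at a limit like compound 1 and compound 2, so no step among them can be read: the limit of > 30000 nM in this assay, at which 3 of the 3 values shown sit. The compounds shown leave open how far any of them lies past that limit in this assay.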